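A few compounds are considered here, and "the series" means these few. Any claim that something is new, unique, unknown or untested is made for them only; others in the source may bear on it.

Measured so far:
compound 1 `Oc1cccc(-c2cc(-c3ccccc3)cc(-c3cccs3)n2)c1` — 5.8%
compound 2 `Oc1ccc(-c2cc(-c3ccccc3)cc(-c3cccs3)n2)cc1` — "not determined" (no result reported)

In an assay on isolated protein for inhibition of DNA topoisomerase 1 (Homo sapiens), with a stated time of 30 min, tested at 20 uM (a lower number here means a weaker effect, a higher number a stronger effect of the compound at the concentration tested), compound 1 gives 5.8%, a weak effect at the concentration tested. Within the data shown here, for compound 2 this assay gives "not determined" (no result reported), so compound 2 stands on no number of its own; the value of compound 1 is the only guide for the series. Compound 3 `Oc1ccc(-c2cc(-c3ccccc3)cc(-c3cccnc3)n2)cc1` differs from compound 2 by pyridin-3-yl in place of thiophen-2-yl on an aromatic carbon. Among the measured compounds shown here, no measured step of this kind is available, so in this assay no step beyond the scatter is expected, in either direction. Compound 3 is expected to give about 8% in this assay, within 0% to 25%.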

Compound 3, a percentage reported as inhibition, at one concentration (the size of the read-out at that concentration, not a potency): 0.9%
For compound 3 the middle estimate is 7.1 percentage points above the measured one; low and high end bracket the measured number.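

Among these compounds, with compound 2 at "not determined" (no result reported) in this assay, no step from compound 2 to compound 3 can be read. The compounds shown leave open what pyridin-3-yl in place of thiophen-2-yl does to this read-out. No evidence bears on the result.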